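Swapping Dimethylamino for a Small Ring on the Shared Core

The compounds below may be only part of what the source reports. "The series", "measured", "known", "first", "only" and "open" are said of these compounds alone.

Measured so far:
compound 1 `CN(C)c1ccc2cc(NC(=O)CCc3ccc(C(F)(F)F)cc3)ccc2n1`: 110 nM
compound 2 `Nc1ccc2cc(NC(=O)CCc3ccc(C(F)(F)F)cc3)ccc2n1`: 720 nM
compound 3 `CNC(=O)NC1CCN(c2ccc3cc(NC(=O)CCc4ccc(C(F)(F)F)cc4)ccc3n2)C1`: 30 nM

These three compounds share one core and differ only in the amine group attached to one aromatic carbon of that core. In a functional assay on HEK293 cells for activation of melanin-concentrating hormone receptor 1 (Rattus norvegicus), read by inositol phosphate accumulation (a higher number here means that more compound is needed for the effect, a lower number that less compound is needed), compound 1 gives 110 nM and stands second highest of the three numbers. Its nearest neighbour is reached by a 3.7-fold lower number from compound 1 to compound 3 (0.56 log units; beyond the scatter), its furthest by a 6.5-fold higher number from compound 1 to compound 2 (0.82 log units; beyond the scatter).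

Compound 4 `CC1CCCN1c1ccc2cc(NC(=O)CCc3ccc(C(F)(F)F)cc3)ccc2n1` has not yet been measured. Compared with compound 1, the change is 2-methylpyrrolidin-1-yl in place of dimethylamino on an aromatic carbon. Both measured steps out of compound 1 bear on this. Cutting the group down to amino gave a 6.5-fold higher number from compound 1 to compound 2 (0.82 log units; beyond the scatter), while exchanging it for a larger ring-bearing group gave a 3.7-fold lower number from compound 1 to compound 3 (0.56 log units; beyond the scatter). Among the measured compounds shown here, the new group in compound 4 resembles the one in compound 3 in that it brings a five-membered non-aromatic ring with 1 hetero atom and 0 hydrogen-bond donors, but it lacks the methylcarbamoylamino part that compound 3 carries, so the lowering seen with compound 3 may be only partly reproduced.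

Compound 4 is therefore expected to give about 60 nM, with a likely range from 20 nM to 200 nM. This estimate corresponds to an expected 1.8-fold lower number from compound 1 to compound 4 (0.26 log units; within the scatter).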

Compound 4, half-maximal effective concentration: 270 nM
The estimate for compound 4 lay 4.5-fold (0.65 log units) below the measured number; measured number above the stated range.
By their numbers in this assay, from the lowest: compound 3; then compound 1; then compound 4; then compound 2.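

A ring at this position does not by itself lower the number: in this assay, putting 2-methylpyrrolidin-1-yl in place of dimethylamino gives a 2.5-fold higher number from compound 1 to compound 4 (0.39 log units; beyond the scatter) and so moves the opposite way from the ring-bearing group of compound 3. Sharing a five-membered non-aromatic ring with 1 hetero atom also does not make two groups behave alike, as the exchange of 3-((methylcarbamoyl)amino)pyrrolidin-1-yl for 2-methylpyrrolidin-1-yl gives a 9.0-fold higher number from compound 3 to compound 4 (0.95 log units; beyond the scatter) in this same read-out. The new group still improves on amino, with a 2.7-fold lower number from compound 2 to compound 4 (0.43 log units; beyond the scatter), but the number does not fall steadily as the group grows, and compound 4 is the one that goes against such a trend.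

From the compounds shown here alone, an unsubstituted pyrrolidin-1-yl would separate the contribution of the ring from that of its methyl, and how it compares with dimethylamino remains open. Also open, going by these compounds, is whether the methylcarbamoylamino part needs its ring position, or whether a simpler acetamido or hydroxyl group on the same ring would give a similarly low number. Nothing available here explains why this group gives a higher number than dimethylamino.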